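The source may hold more compounds than are shown below. What is called first, only, known or untested is meant among the compounds shown, and "the series" means these compounds.

Working notes on the series. Compound 1 `Cc1cnc(Nc2ccc(S(N)(=O)=O)cc2)nc1Nc1nc2ccccc2s1` gives 1660 nM in a functional assay on HCT-116 cells (Homo sapiens) for antiproliferative activity, read by MTT assay, with a stated time of 48 h (a lower number here means a stronger inhibitor, a higher number a weaker inhibitor), and stands with the lowest number of the three measured compounds, both of the others being beyond the scatter from it. Compound 2 `NS(=O)(=O)c1ccc(Nc2nccc(Nc3nc4ccccc4s3)n2)cc1` gives 5170 nM in this assay, and compound 3 `COc1ccc2nc(Nc3nc(Nc4ccc(S(N)(=O)=O)cc4)ncc3C)sc2c1` gives 7860 nM. The two measured steps both start from compound 1: a 3.1-fold higher number from compound 1 to compound 2 (0.49 log units; beyond the scatter), and a 4.7-fold higher number from compound 1 to compound 3 (0.68 log units; beyond the scatter). Each is a change at a single aromatic carbon, and each raises the number beyond the scatter.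

Compound 4 `Cc1cnc(Nc2ccc(N3CCCCC3)cc2)nc1Nc1nc2ccccc2s1` differs from compound 1 as follows: piperidin-1-yl in place of sulfamoyl on an aromatic carbon. Neither measured step covers this exchange; the steps to compound 2 and to compound 3 alter other positions and keep the sulfamoyl, so they give no guide to what happens when it is replaced. The direction of the change in this assay therefore cannot be read from the measured compounds, and the uncertainty is wide. As a working assumption compound 4 is expected to land near compound 1, the estimate for compound 4 in this assay being 2500 nM. The expected range for compound 4 runs from 500 nM to 12000 nM. This estimate corresponds to an expected step of a 1.5-fold higher number from compound 1 to compound 4 (0.18 log units; within the scatter).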

Compound 4, half-maximal inhibitory concentration: 18700 nM
Beside the measured number, compound 4's estimate is 7.5-fold (0.87 log units) below it, outside the stated range (above it).
By their numbers in this assay, from the lowest: compound 1; then compounds 2 and 3 (each within the scatter of the next); then compound 4.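

For the compounds shown here, the exchange of sulfamoyl for piperidin-1-yl on the six-membered aromatic ring of carbon only is the first measured change at this position, and an 11-fold higher number from compound 1 to compound 4 (1.05 log units; beyond the scatter) in this assay shows that the number is sensitive to the group carried there. This step is large, while the two earlier steps at other places on compound 1, a 3.1-fold higher number from compound 1 to compound 2 (0.49 log units; beyond the scatter) and a 4.7-fold higher number from compound 1 to compound 3 (0.68 log units; beyond the scatter), are modest, so among the single changes shown this one moves the number furthest. No measurement in hand accounts for the size of this step.

The exchange changes several counted features at once: the entering group has a non-aromatic ring, more heavy atoms and no hydrogen-bond donors, so this single pair cannot show which of these differences matters. On these data alone, it remains open whether a primary amine, a carboxylic acid or a morpholin-4-yl group at this position would stay close to compound 1, and whether replacing sulfamoyl costs as much on the cores of compound 2 and compound 3.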